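The compounds below may be only part of what the source reports. "The series", "measured", "known", "first", "only" and "open" are said of these compounds alone.

Measured in a functional assay on A549 cells (Homo sapiens) for antiproliferative activity, read by MTT assay, with a stated time of 48 h; on this read-out lower numbers stand for stronger inhibition and higher numbers for weaker inhibition:
- compound 1 `CC(C)=CCC[C@]1(C)/C=C/[C@@H](OC(=O)C=C(C)C)[C@](C)(O)/C=C/C(=O)/C(CCl)=C\C1`: 150 nM
- compound 2 `CC(C)=CCC[C@]1(C)/C=C/[C@@H](OC(=O)C=C(C)C)[C@](C)(O)/C=C/C(=O)/C(CN2CCCC2)=C\C1`: 180 nM

Compound 2 has only compound 1 as a neighbour on these numbers, and the two values lie within the scatter of each other. Compound 3 `CC(C)=CCC[C@]1(C)/C=C/[C@@H](OC(=O)C=C(C)C)[C@](C)(O)/C=C/C(=O)/C(CN2CCN(C)CC2)=C\C1` has not yet been measured. It carries 4-methylpiperazin-1-yl in place of pyrrolidin-1-yl on a saturated chain carbon bound to a double-bonded ring carbon.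

Going by the values given here, one measured step bears on this change, at the same place, with chloro leaving and pyrrolidin-1-yl entering: a 1.2-fold higher number from compound 1 to compound 2 (0.08 log units; within the scatter). That single step stayed within the scatter, so no shift beyond the scatter is expected in this assay, and no direction can be argued from it. The expected step is a 1.1-fold higher number from compound 2 to compound 3 (0.05 log units; within the scatter). For compound 3 the estimated value is 200 nM, with an expected range of 90 nM to 450 nM.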

Compound 3, half-maximal inhibitory concentration: 940 nM
The estimate for compound 3 lay 4.7-fold (0.67 log units) below the measured number, and the stated range ends below it.
By their numbers in this assay, from the lowest: compounds 1 and 2 (each within the scatter of the next); then compound 3.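

In this assay, the group on this saturated chain carbon turns out to matter: a 5.2-fold higher number from compound 2 to compound 3 (0.72 log units; beyond the scatter) means weaker inhibition, and a 6.3-fold higher number from compound 1 to compound 3 (0.80 log units; beyond the scatter) shows the same against chloro, whereas a 1.2-fold higher number from compound 1 to compound 2 (0.08 log units; within the scatter) had shown no separation. Replacing chloro with a cyclic amine therefore does not by itself weaken inhibition, since the outcome depends on which ring enters. No available evidence accounts for the difference between pyrrolidin-1-yl and 4-methylpiperazin-1-yl.

The change alters ring size, the second ring nitrogen and its methyl group at once, so the compounds shown cannot assign the loss to any one of these. Going by these compounds, whether piperidin-1-yl, morpholin-4-yl or piperazin-1-yl without the methyl group would behave like pyrrolidin-1-yl or like 4-methylpiperazin-1-yl remains open.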